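A few compounds are considered here, and "the series" means these few. Any claim that something is new, unique, unknown or untested is made for them only; others in the source may bear on it.

Measured so far:
compound 1, `Oc1ccc(-c2cc(-c3ccco3)cc(-c3ccccc3O)n2)cc1`: 83%
compound 2, `Oc1cccc(-c2cc(-c3ccco3)cc(-c3cccc(O)c3)n2)c1`: 97.8%
compound 3, `Oc1ccc(-c2cc(-c3ccco3)cc(-c3cccc(O)c3)n2)cc1`: 100%

In an assay on isolated protein for inhibition of DNA topoisomerase 1 (Homo sapiens), with a stated time of 30 min, tested at 100 uM (a higher number here means a stronger effect of the compound at the concentration tested, a lower number a weaker effect), compound 3 holds the highest of the three numbers. The step of a number 17 percentage points higher from compound 1 to compound 3 (beyond the scatter) lies beyond the scatter, whereas a number 2.2 percentage points higher from compound 2 to compound 3 (within the scatter) lies within it, so compound 2 and compound 3 cannot be told apart on these numbers.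

Compound 4, `Oc1ccc(-c2cc(-c3ccccn3)cc(-c3cccc(O)c3)n2)cc1`, differs from compound 3 in one place: pyridin-2-yl in place of furan-2-yl on an aromatic carbon. Neither measured step touches this group; both concern only the hydroxyphenyl groups, so no direct guide exists. Since compound 3 already sits at the top of the scale at 100%, a rise cannot show. A step of a number 8 percentage points lower from compound 3 to compound 4 (within the scatter) is expected, that is nothing beyond the scatter or a small drop. Compound 4 is expected to give 92%, between 75% and 100%.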

Compound 4, a percentage reported as inhibition, at one concentration (the size of the read-out at that concentration, not a potency): 2.4%
The estimate for compound 4 lay 89.6 percentage points above the measured number, and the stated range ends above it.
By their numbers in this assay, from the lowest: compound 4; then compound 1; then compounds 2 and 3 (each within the scatter of the next).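

In this assay, the group opposite the ring nitrogen proves decisive: pyridin-2-yl in place of furan-2-yl gives a step of a number 97.6 percentage points lower from compound 3 to compound 4 (beyond the scatter), whereas the hydroxyphenyl changes gave no more than a number 17 percentage points higher from compound 1 to compound 3 (beyond the scatter). Both groups carry one hetero atom and one hydrogen-bond acceptor, so these counts do not separate compound 3 from compound 4. No measured evidence bears on the reason for this step.

Still open, as far as these compounds go, is whether a phenyl or thiophen-2-yl group at this position would keep the read-out of compound 3. Also open, from the compounds shown here alone, is whether the hydroxyphenyl steps would hold with pyridin-2-yl in place.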